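An imine aryl swap at the assay limit

The compounds below may be only part of what the source reports. "The series", "measured", "known", "first", "only" and "open" are said of these compounds alone.

Compound 1 `CCOC(=O)/C=N/c1cnc(Nc2ccc(S(N)(=O)=O)cc2)nc1NC(C)C` and compound 2 `CC(C)Nc1nc(Nc2ccc(S(N)(=O)=O)cc2)ncc1/N=C/c1cccs1` share one core and differ only at a carbon with a double bond to nitrogen. In a functional assay on HT-29 cells (Homo sapiens) for antiproliferative activity, read by MTT assay (a lower number here means a stronger inhibitor, a higher number a weaker inhibitor), compound 1 gives > 100000 nM, which is a limit of the assay and not a number. In this assay compound 2 gives > 100000 nM, again a limit rather than a measured number. The change from ethoxycarbonyl to thiophen-2-yl on that carbon therefore cannot be read: a step that the two limits leave unreadable from compound 1 to compound 2. Among the measured compounds shown here, compound 2 thus stands at the limit, and the limit of > 100000 nM in this assay, at which 2 of the 2 values shown sit, shows that both values so far sit there.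

Compound 3 `CC(C)Nc1nc(Nc2ccc(S(N)(=O)=O)cc2)ncc1/N=C/c1ccc(C(F)(F)F)cc1` carries the change (4-(trifluoromethyl)phenyl in place of thiophen-2-yl on a carbon with a double bond to nitrogen). For the measured compounds named here, no measured step bears on this change in a readable way, since the only step available, a step that the two limits leave unreadable from compound 1 to compound 2, is itself unreadable, and the two values give no size to build on. Compound 3 is therefore expected to remain at the limit, with an estimate of 100000 nM and a range from 20000 nM to 500000 nM. The step from compound 2 to compound 3 is expected to be a number no higher from compound 2 to compound 3 (the limit leaves the size open), with no change beyond the scatter expected.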

Compound 3, half-maximal inhibitory concentration: > 100000 nM
Compound 3 ended at the assay's limit (the forecaster's own chance of this, stated with the estimate: 80%); the middle value lies on the limit itself.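

Compound 1, compound 2 and compound 3 all stand at a limit rather than at a number, so no step among them can be read in this assay: the limit of > 100000 nM in this assay, at which 3 of the 3 values shown sit.

The compounds shown leave open whether any group on the carbon with a double bond to nitrogen changes the result in this assay at all, and by how much.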